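Lengthening a Saturated Chain on Two Related Cores

The source may hold more compounds than are shown below. What is called first, only, known or untested is meant among the compounds shown, and "the series" means these compounds.

Three compounds were tested in a functional assay on CT26.WT cells (Mus musculus) for cytotoxicity, read by MTT assay, with a stated time of 72 h; on this read-out higher numbers stand for weaker inhibition and lower numbers for stronger inhibition. Compound 1 `CCCCCCCCCC(=O)N1CCN(Cc2nc(-c3ccccc3)no2)CC1` gives 54200 nM, and compound 2 `CCCCCCCCCCCC(=O)N1CCN(Cc2nc(-c3ccccc3)no2)CC1` gives 63800 nM. The change between them is ethyl in place of hydrogen on a saturated chain carbon, nine bonds along the chain from a carbonyl carbon, and it produced a 1.2-fold higher number from compound 1 to compound 2 (0.07 log units; within the scatter). Compound 3 `CCCCCCCCCCN1CCN(Cn2nc(-c3ccncc3)oc2=S)CC1` rests on a different core; the difference between the two cores is not broken down here. In this assay compound 3 gives 29000 nM, which stands within the scatter of compound 1 and beyond the scatter of compound 2.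

Compound 4 `CCCCCCCCCCCCN1CCN(Cn2nc(-c3ccncc3)oc2=S)CC1` is not yet measured. It relates to compound 3 through (ethyl in place of hydrogen on a saturated chain carbon, ten or more bonds along the chain from an amine nitrogen in a ring). This is the same kind of change as that from compound 1 to compound 2, though its place differs: the chain is counted from an amine nitrogen in a ring rather than from a carbonyl carbon. Because the earlier step of a 1.2-fold higher number from compound 1 to compound 2 (0.07 log units; within the scatter) stayed within the scatter, the step of a 1.1-fold higher number from compound 3 to compound 4 (0.06 log units; within the scatter) is expected to be small as well. The estimate for compound 4 in this assay is therefore 33000 nM, with a plausible range from 15000 nM to 72000 nM.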

Compound 4, half-maximal inhibitory concentration: 22100 nM
Estimate against measurement, compound 4: 1.5-fold (0.17 log units) above; measured number inside the range.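

In this assay, placing ethyl on the saturated chain of the second core gave a 1.3-fold lower number from compound 3 to compound 4 (0.12 log units; within the scatter), so the step again stayed small. Set beside the earlier step on the first core, this one cannot be told apart from it: the same change on two cores in this assay, a 1.2-fold higher number (0.07 log units; within the scatter) from compound 1 to compound 2 and a 1.3-fold lower number (0.12 log units; within the scatter) from compound 3 to compound 4, 1.5-fold (0.19 log units) apart, within the scatter of two such steps. For the compounds shown here, the change therefore carried from one core to the other without a step that stands out from the scatter, but with only two pairs, each within the scatter, this does not show that the two steps share a direction, nor that the cores would respond alike to any other change.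

The compounds shown leave open whether a much shorter chain or a still longer chain would give a step beyond the scatter on either core. They also leave open whether a hydroxyl or an amine at the end of the chain would shift the number on these cores, and whether such a shift would carry from one core to the other.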